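This account rests on a few compounds, and the source may have more. Where it says the series, first, only, none or still open, it means among the compounds named here.

Working notes on the series.

Compound 1 `CCOC(=O)N1CCC(NCCNC(=O)c2ccccc2C)CC1` is recorded in a functional assay for agonist activity at muscarinic acetylcholine receptor M5 (Homo sapiens), read by calcium flux (on this read-out lower numbers stand for an effect already at smaller amounts and higher numbers for an effect only at larger amounts of compound), as "not active" (no number reported), without a number attached. Compound 2 `CCOC(=O)N1C[C@H]2CC[C@@H](C1)[C@H]2NCCNC(=O)c1cccc(Cl)c1` carries the bridged bicyclic carbamate core with the 3-chlorophenyl amide, and in this assay compound 2 gives 4200 nM. That is the only figure in the set; compound 1 adds a further entry without a single number, so compound 2 stands as the sole measured point and no ordering between the two can be drawn from what is shown.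

Compound 3 `CCOC(=O)N1C[C@H]2CC[C@@H](C1)[C@H]2NCCNC(=O)c1ccccc1` is the next entry, not yet measured. Relative to compound 2 the change is hydrogen in place of chloro on an aromatic carbon, the aryl group going from 3-chlorophenyl to phenyl. Among the measured compounds shown here, no measured pair in the set covers such a step, so there is no internal reference for its size or sign. The working expectation is a modest weakening, a step of a 2.1-fold higher number from compound 2 to compound 3 (0.33 log units; beyond the scatter), since the unsubstituted phenyl would be expected to fall off somewhat from the halogenated parent. On that basis compound 3 is estimated at 9000 nM, with a plausible range from 2500 nM to 30000 nM.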

Compound 3, half-maximal effective concentration: 2800 nM
Estimate against measurement, compound 3: 3.2-fold (0.51 log units) above, within the range that was stated.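

In this assay, hydrogen in place of chloro on an aromatic carbon gives a 1.5-fold lower number from compound 2 to compound 3 (0.18 log units; within the scatter), so 3-chlorophenyl and phenyl cannot be told apart at this place on the shared core. Among the compounds shown here, this is the first reading of this position, and it shows that a measurable response does not depend on the chloro group, since compound 3 also returns a number, like compound 2. Nothing available explains why the two compounds read alike.

The compounds shown leave open whether any other group on this aromatic carbon, such as a methoxy group, an amine or a carboxylic acid, would move the number beyond the scatter, as one substituent and its removal say little about the position as a whole. Compound 1 differs from compound 2 and compound 3 in more than one place, so its entry without a number cannot be read as a step, and it remains unclear which of its differences goes with that outcome.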